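A few compounds are considered here, and "the series" means these few. Any claim that something is new, unique, unknown or untested is made for them only; others in the source may bear on it.

Of the compounds shown here, three built on the same core have been measured in an assay on NIH3T3 cells with melatonin receptor type 1B (Homo sapiens) as the target; on this read-out higher numbers stand for weaker inhibition and lower numbers for stronger inhibition. Compound 1 `CCCC1Nc2cccc([C@@H]3C[C@H]3CNC(=O)C(C)C)c2O1` gives 0.28 nM, compound 2 `CCC(=O)NC[C@@H]1C[C@H]1c1cccc2c1OC(C(C)C)N2` gives 0.32 nM, and compound 3 `CC(C)C(=O)NC[C@@H]1C[C@H]1c1cccc2c1OC(C(C)C)N2` gives 2.5 nM. On these numbers compound 3 stands highest, meaning weakest, and both steps leading to it are beyond the scatter: an 8.9-fold higher number from compound 1 to compound 3 (0.95 log units; beyond the scatter) and a 7.8-fold higher number from compound 2 to compound 3 (0.89 log units; beyond the scatter). Compound 4 `CNC(=O)NC[C@@H]1C[C@H]1c1cccc2c1OC(C(C)C)N2` has not yet been measured. It differs from compound 3 by methylamino in place of isopropyl on a carbonyl carbon. The step from compound 2 to compound 3 bears most directly on this, since that step put a methyl in place of hydrogen and the change to compound 4 removes the isopropyl altogether. Going by the values given here, no measured step swaps an amide for a urea, so the change is only partly covered by what has been seen. The expectation is that compound 4 moves back toward the lower numbers of compound 2, giving a 4.2-fold lower number from compound 3 to compound 4 (0.62 log units; beyond the scatter). Compound 4 is therefore estimated at 0.6 nM, with a likely range from 0.15 nM to 3 nM.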

Compound 4, inhibition constant: 12.6 nM
Compound 4: the middle estimate sits 21-fold (1.32 log units) below what was measured; measured number above the stated range.
By their numbers in this assay, from the lowest: compounds 1 and 2 (each within the scatter of the next); then compound 3; then compound 4.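

In this assay, a shorter group on the carbonyl carbon does not bring back the low numbers: methylamino in place of isopropyl gives a 5.0-fold higher number from compound 3 to compound 4 (0.70 log units; beyond the scatter) and methylamino in place of ethyl gives a 39-fold higher number from compound 2 to compound 4 (1.60 log units; beyond the scatter) at the same place. The number here therefore does not follow heavy-atom count alone, since methylamino has fewer heavy atoms than isopropyl yet compound 4 sits above compound 3; the change also brings in a nitrogen and a hydrogen-bond donor, and these compounds cannot separate those features. Nothing measured explains this rise.

An unsubstituted amino group, a dimethylamino group or a methoxy group on this carbonyl carbon would show whether the nitrogen, its hydrogen or its methyl matters. As far as these compounds go, it also stays open whether methylamino behaves the same with the propyl group of compound 1 in place of isopropyl on the saturated ring carbon.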